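Furan-2-yl replacing pyridin-3-yl in a cytotoxicity series

The source may report more compounds than this note shows. Statements on the series, on what has been measured and on what is new or still open speak of the compounds shown alone.

Compound 1 `CCOC(=O)CCCCCOc1cccc(CN(C(=O)c2ccc(-c3ccc4ccccc4c3)cc2)C(C)C)c1` gives > 26000 nM in an ADME assay on HEK293 cells (Homo sapiens) for cytotoxicity, read by CellTiter-Glo and resazurin assay, with a stated time of 72 h; a lower number here means that less compound is needed, a higher number that more compound is needed for the effect.
Compound 2 `CCOC(=O)CCCCCOc1cccc(CN(C(=O)c2ccc(-c3cccnc3)cc2)C(C)C)c1` gives > 26000 nM in this assay.

The value for compound 1 is a limit of the assay rather than a number. The value for compound 2 is likewise a limit. The step that the two limits leave unreadable from compound 1 to compound 2 is therefore not readable, since both values sit at the limit of > 26000 nM in this assay, at which 2 of the 2 values shown sit. Compound 2 thus stands at this limit, without a measured number of its own.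

Compound 3 `CCOC(=O)CCCCCOc1cccc(CN(C(=O)c2ccc(-c3ccco3)cc2)C(C)C)c1` differs from compound 2 by furan-2-yl in place of pyridin-3-yl on an aromatic carbon. Going by the values given here, no measured step bears readably on this change, because the only comparison available rests on (the limit of > 26000 nM in this assay, at which 2 of the 2 values shown sit). Compound 3 is therefore expected to stay at the same limit, which means an expected step of a number no higher from compound 2 to compound 3 (the limit leaves the size open) in this assay, none beyond the scatter. The estimate for compound 3 is 26000 nM, expected to fall between 13000 nM and 60000 nM, most likely reported only as a limit.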

Compound 3, half-maximal effective concentration: > 26000 nM
Compound 3 was reported as a limit (the forecaster's own chance of this, stated with the estimate: 85%); the middle value sits exactly at the limit.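

Compound 1, compound 2 and compound 3 all stop at the same limit of the assay, so no step between them can be read: the limit of > 26000 nM in this assay, at which 3 of the 3 values shown sit.

The compounds shown leave open whether naphthalen-2-yl, pyridin-3-yl and furan-2-yl differ at all in this assay, and at what concentration any of the three compounds would reach the half-maximal effect.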